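Fluoro Step Repeated on a Second Core in Hepatocytes

The compounds below may be only part of what the source reports. "The series", "measured", "known", "first", "only" and "open" are said of these compounds alone.

Measured so far:
compound 1, `CC(=O)N[C@@H]1CCC[C@H](C(=O)Nc2cc(-c3cnn4c3CCCC4)ccn2)C1`: 33 uL/min
compound 2, `CC(=O)N[C@@H]1CCC[C@H](C(=O)Nc2cc(-c3cnn4c3CCCC4)c(F)cn2)C1`: 73 uL/min
compound 3, `CC(=O)N[C@@H]1CCC[C@H](C(=O)Nc2cc(-c3cnn4c3CC(C)(C)CC4)ccn2)C1`: 35 uL/min

All three were run in an ADME assay on cells (Hepatocyte, Rattus norvegicus) for metabolic stability, using equilibrium dialysis; on this read-out lower numbers stand for slow clearance and higher numbers for fast clearance. Compound 1 and compound 2 share one core and differ in a single place: fluoro in place of hydrogen on an aromatic carbon. This change brings a 2.2-fold higher number from compound 1 to compound 2 (0.34 log units; beyond the scatter). Compound 3 carries a second core; the difference between the core of compound 1 and the core of compound 3 is not broken down here. In this assay compound 3 and compound 1 lie within the usual scatter of each other, while compound 3 stands beyond the scatter from compound 2.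

Compound 4, `CC(=O)N[C@@H]1CCC[C@H](C(=O)Nc2cc(-c3cnn4c3CC(C)(C)CC4)c(F)cn2)C1`, is not yet measured. It relates to compound 3 as compound 2 relates to compound 1: fluoro in place of hydrogen on an aromatic carbon. The surroundings are described alike on both cores except in one respect: on the core of compound 1 the carbon is ortho to a group of 9 heavy atoms, whereas on the core of compound 3 it is ortho to a large group. The change is therefore the same kind of change, made on a different core, and with a single prior instance there is no basis for expecting it to behave differently.

Compound 4 is expected to show a step in this assay of a 2.1-fold higher number from compound 3 to compound 4 (0.33 log units; beyond the scatter), resting on a 2.2-fold higher number from compound 1 to compound 2 (0.34 log units; beyond the scatter). Among the compounds with values here, compound 4 is accordingly estimated at 75 uL/min, with an expected range from 45 uL/min to 125 uL/min, the spread reflecting that one earlier step is the only guide.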

Compound 4, intrinsic clearance in a liver preparation (reported as CLH), per the amount of preparation that the assay uses in the Hepatocyte assay: 42 uL/min
Compound 4: middle estimate off by 1.8-fold (0.25 log units), on the high side, outside the stated range (below it).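

In the Hepatocyte assay the same fluoro in place of hydrogen on an aromatic carbon, now on the core of compound 3, gives a 1.2-fold higher number from compound 3 to compound 4 (0.08 log units; within the scatter), and set beside the earlier step the two do not separate: the same change on two cores in the Hepatocyte assay, a 2.2-fold higher number (0.34 log units; beyond the scatter) from compound 1 to compound 2 and a 1.2-fold higher number (0.08 log units; within the scatter) from compound 3 to compound 4, 1.8-fold (0.27 log units) apart, within the scatter of two such steps The new step alone lies within the scatter and the earlier one beyond it, but the gap between them also lies within the scatter, so these two pairs do not show that the core alters the effect of the change, nor do they fix a size for it that carries reliably from one core to the other. In a physicochemical assay for lipophilicity, using the shake flask method, measured as octanol-water partition, at pH 7.4 (on this read-out higher numbers stand for higher lipophilicity and lower numbers for lower lipophilicity), compound 3 gives 3.1 and compound 4 gives 3.6, a gap beyond the scatter, yet a single pair on this read-out cannot tie that gap to the step in the Hepatocyte assay.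

Open, on these data alone, is whether a chloro or a nitrile in place of the fluoro on that aromatic carbon would move either read-out in the same way. Also open, as far as these compounds go, is how the step behaves when a hydroxyl or an amine stands in place of the methyl groups on the core of compound 3.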